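Five-membered heteroaryl swap on the chlorophenyl arm

The compounds below may be only part of what the source reports. "The series", "measured", "known", "first", "only" and "open" are said of these compounds alone.

Measured in an assay on isolated protein for inhibition of ubiquitin carboxyl-terminal hydrolase 7 (Homo sapiens), with stated times of 30 min and 2 h; a higher number here means a weaker inhibitor, a lower number a stronger inhibitor:
compound 1 `Cn1nc2c(=O)n(CC3(O)CCN(Cc4ccc(-c5cnco5)cc4Cl)CC3)cnc2c1-c1ccc(CN)cc1` — 71.6 nM
compound 2 `Cn1nc2c(=O)n(CC3(O)CCN(Cc4ccc(-c5ncco5)cc4Cl)CC3)cnc2c1-c1ccc(CN)cc1` — 1120 nM
compound 3 `Cn1nc2c(=O)n(CC3(O)CCN(Cc4ccc(-c5ccco5)cc4Cl)CC3)cnc2c1-c1ccc(CN)cc1` — 18.1 nM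

Compound 3 holds the lowest number of the three, with a 4.0-fold lower number from compound 1 to compound 3 (0.60 log units; beyond the scatter) and a 62-fold lower number from compound 2 to compound 3 (1.79 log units; beyond the scatter) both beyond the scatter. Compound 4 `Cn1nc2c(=O)n(CC3(O)CCN(Cc4ccc(-c5cncs5)cc4Cl)CC3)cnc2c1-c1ccc(CN)cc1` differs from compound 3 by 1,3-thiazol-5-yl in place of furan-2-yl on an aromatic carbon. For the measured compounds named here, the steps that bear on this change are a 4.0-fold lower number from compound 1 to compound 3 (0.60 log units; beyond the scatter), a modest one, and a 62-fold lower number from compound 2 to compound 3 (1.79 log units; beyond the scatter), a large one; both replace a ring with two hetero atoms by furan-2-yl. The ring entering in compound 4 is closest to the 1,3-oxazol-5-yl of compound 1, so a modest rise in this assay from compound 3 is expected rather than the large one seen with compound 2. The expected step is a 2.2-fold higher number from compound 3 to compound 4 (0.34 log units; beyond the scatter). Compound 4 is estimated at 40 nM, range 12 nM to 130 nM.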

Compound 4, half-maximal inhibitory concentration: 117 nM
Estimate against measurement, compound 4: 2.9-fold (0.47 log units) below, and the stated range covers the measured number.
By their numbers in this assay, from the lowest: compound 3; then compounds 1 and 4 (each within the scatter of the next); then compound 2.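

In this assay, 1,3-thiazol-5-yl gives up most of what furan-2-yl gains (a 6.5-fold higher number from compound 3 to compound 4 (0.81 log units; beyond the scatter)), while the step from the oxazole of compound 1 stays within the scatter (a 1.6-fold higher number from compound 1 to compound 4 (0.21 log units; within the scatter)). A second hetero atom in the ring therefore does not by itself bring the large loss seen with 1,3-oxazol-2-yl (a 9.6-fold lower number from compound 2 to compound 4 (0.98 log units; beyond the scatter)). Among these four rings, furan-2-yl alone stands clear of the others.

Open, going by these compounds, is whether thiophen-2-yl, or a non-ring group such as an amine or a carboxylic acid, at this place would match compound 3. Nothing shown here accounts for the differences between these rings.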